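This account rests on a few compounds, and the source may have more. Where it says the series, first, only, none or still open, it means among the compounds named here.

Series notes, cytotoxicity on a lung carcinoma line.

Compound 1 `COc1cc2c(Oc3ccc(NC(=O)c4nn(-c5ccccc5C(F)(F)F)c(=O)cc4C)cc3F)ccnc2cc1OCCCN1CCCC1` gives 210 nM in a functional assay on NCI-H460 cells (Homo sapiens) for inhibition, read by MTT assay, with a stated time of 72 h; a lower number here means a stronger inhibitor, a higher number a weaker inhibitor. Compound 2 `COc1cc2c(Oc3ccc(NC(=O)c4nn(-c5ccccc5C(F)(F)F)c(=O)cc4C)cc3F)ccnc2cc1OCCCN1CCCCC1` differs from compound 1 only by piperidin-1-yl in place of pyrrolidin-1-yl on a saturated chain carbon, three bonds along the chain from an oxygen on an aromatic ring; in this assay compound 2 gives 210 nM, and the step of no change at the digits printed from compound 1 to compound 2 (within the scatter). Compound 3 `COc1cc2c(Oc3ccc(NC(=O)c4nn(-c5cccc(F)c5)c(=O)cc4C)cc3F)ccnc2cc1OCCCN1CCCC1` keeps the same chain and terminal ring as compound 1 but differs at the aromatic nitrogen by 3-fluorophenyl in place of 2-(trifluoromethyl)phenyl on an aromatic nitrogen; in this assay compound 3 gives 280 nM, so that a 1.3-fold higher number from compound 1 to compound 3 (0.12 log units; within the scatter). All three measured values therefore sit inside the usual scatter of one another, and none of the three can be called the strongest or weakest inhibitor on this evidence.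

Compound 4 `COc1cc2c(Oc3ccc(NC(=O)c4nn(-c5cccc(F)c5)c(=O)cc4C)cc3F)ccnc2cc1OCCCN1CCCCC1` is not yet measured in this assay. It stands to compound 3 as compound 2 stands to compound 1: the change is piperidin-1-yl in place of pyrrolidin-1-yl on a saturated chain carbon, three bonds along the chain from an oxygen on an aromatic ring, and the place description is the same word for word as for the change from compound 1 to compound 2, so it is the same change carried onto the core of compound 3. The only cores involved differ by 3-fluorophenyl in place of 2-(trifluoromethyl)phenyl on an aromatic nitrogen. For the measured compounds named here, on the single precedent, where the step of no change at the digits printed from compound 1 to compound 2 (within the scatter), the expected step is no change at the digits printed from compound 3 to compound 4 (within the scatter), resting on compound 1 and compound 2 alone, since no second example of this change is available. For compound 4 in this assay the estimate is 280 nM, with a likely range from 150 nM to 520 nM.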

Compound 4, half-maximal inhibitory concentration: 360 nM
Beside the measured number, compound 4's estimate is 1.3-fold (0.11 log units) below it; the range from low to high includes it.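

In this assay, the exchange of pyrrolidin-1-yl for piperidin-1-yl on the core of compound 3 reads as a 1.3-fold higher number from compound 3 to compound 4 (0.11 log units; within the scatter), and this agrees with the same exchange on the core of compound 1: the same change on two cores in this assay, no change at the digits printed (within the scatter) from compound 1 to compound 2 and a 1.3-fold higher number (0.11 log units; within the scatter) from compound 3 to compound 4, 1.3-fold (0.11 log units) apart, within the scatter of two such steps. The exchange of 2-(trifluoromethyl)phenyl for 3-fluorophenyl on the aromatic nitrogen, carried onto the piperidin-1-yl compounds, reads as a 1.7-fold higher number from compound 2 to compound 4 (0.23 log units; within the scatter), and this also agrees with its earlier counterpart: the same change on two cores in this assay, a 1.3-fold higher number (0.12 log units; within the scatter) from compound 1 to compound 3 and a 1.7-fold higher number (0.23 log units; within the scatter) from compound 2 to compound 4, 1.3-fold (0.11 log units) apart, within the scatter of two such steps. Within these four compounds, each change therefore carries from one core to the other without a detectable difference, but every step lies within the scatter, so this shows only agreement between steps too small to resolve, not that the two changes act independently in general or on any further core.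

Still open, on these data alone, is whether the same agreement would hold with another terminal amine, such as morpholine or 4-methylpiperazine, or with a chain shorter or longer than 3-(piperidin-1-yl)propyl. Also open, as far as these compounds go, is whether a plain phenyl, a chlorophenyl or a pyridyl group on the aromatic nitrogen would give a step large enough to test the carry-over beyond the scatter.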